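Only the aromatic amine keeps a number

The compounds below may be only part of what the source reports. "The series", "measured", "known", "first", "only" and "open" are said of these compounds alone.

Compound 1 `Cc1ccc(NC2=CC(=O)c3c(nc4n3[C@H]3OC[C@@H](O)[C@H]3OC4)C2=O)cc1C`: 1050 nM
Compound 2 `O=C1C(N2CCCC2)=CC(=O)c2c1nc1n2[C@H]2OC[C@@H](O)[C@H]2OC1`: > 16000 nM (a limit)
Compound 3 `O=C1C(N2CCC2)=CC(=O)c2c1nc1n2[C@H]2OC[C@@H](O)[C@H]2OC1`: > 16000 nM (a limit)

Among the compounds with values here, in a functional assay on MGC-803 cells (Homo sapiens) for inhibition, read by sulforhodamine B assay (a higher number here means a weaker inhibitor, a lower number a stronger inhibitor), compound 1 gives 1050 nM, the only true number here. Compounds 2 and 3 stop at a limit of the assay: the limit of > 16000 nM in this assay, at which 2 of the 3 values shown sit.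

Compound 4 `CCCc1ccc(NC2=CC(=O)c3c(nc4n3[C@H]3OC[C@@H](O)[C@H]3OC4)C2=O)cc1`, not yet measured, differs from compound 1 in one group: 4-propylphenyl in place of 3,4-dimethylphenyl on an amine nitrogen. Within the data shown here, two measured steps bear on this only loosely, an at least 15-fold higher number from compound 1 to compound 2 (1.18 log units; beyond the scatter) and an at least 15-fold higher number from compound 1 to compound 3 (1.18 log units; beyond the scatter). Both were large, and both replaced the whole (3,4-dimethylphenyl)amino group with a saturated ring. Among the measured compounds shown here, compound 4 keeps its amine nitrogen and aromatic ring, and no measured step swaps one such ring substituent for another. A small change is therefore expected, not beyond the scatter: a 1.3-fold higher number from compound 1 to compound 4 (0.12 log units; within the scatter). For compound 4 the estimate is 1400 nM, with an expected range of 450 nM to 4500 nM.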

Compound 4, half-maximal inhibitory concentration: 1920 nM
Compound 4: middle estimate off by 1.4-fold (0.14 log units), on the low side; the measured number falls inside the stated range.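

The change from 3,4-dimethylphenyl to 4-propylphenyl on the amine nitrogen gives a 1.8-fold higher number from compound 1 to compound 4 (0.26 log units; within the scatter) in this assay and does not separate the two compounds. Compound 4 thus joins compound 1 as an aromatic amine with a true number, while compounds 2 and 3, with saturated rings, stop at a limit. Nothing shown gives a reason for this small step.

On these data alone, what a longer chain such as hexyl in place of propyl would do remains open. So does the effect of a carboxylic acid on the phenyl ring.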